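The compounds below may be only part of what the source reports. "The series", "measured", "known", "first", "only" and "open" are said of these compounds alone.

Measured in a functional assay on HepG2 cells (Homo sapiens) for antiproliferative activity, read by MTT assay, with a stated time of 48 h; on this read-out lower numbers stand for stronger inhibition and higher numbers for weaker inhibition:
- compound 1 `O=C(Nc1ccccc1)Nc1cccc(CNc2nccnc2Cl)c1`: 15600 nM
- compound 2 `O=C(Nc1cccc(CNc2nccnc2Cl)c1)Nc1ccc(F)c(Cl)c1`: 6750 nM
- compound 3 `O=C(Nc1cccc(CNc2nccnc2Cl)c1)Nc1ccc(Cl)cc1Cl`: 7230 nM

Compound 3 stands level with compound 2 and under compound 1 on these numbers. The next compound, compound 4 `Cc1ccc(NC(=O)Nc2cccc(CNc3nccnc3Cl)c2)cc1Cl`, has 3-chloro-4-methylphenyl in place of 2,4-dichlorophenyl on an amide-type nitrogen.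

Two measured steps replace the unsubstituted phenyl and are modest: a 2.3-fold lower number from compound 1 to compound 2 (0.36 log units; beyond the scatter) and a 2.2-fold lower number from compound 1 to compound 3 (0.33 log units; beyond the scatter). Within the data shown here, the closest precedent exchanges one substituted phenyl for another: a 1.1-fold higher number from compound 2 to compound 3 (0.03 log units; within the scatter). On that precedent, no step beyond the scatter is expected in this assay.

The expected step is a 1.0-fold lower number from compound 3 to compound 4 (0.01 log units; within the scatter).

The estimate for compound 4 is 7000 nM, with an expected range of 3500 nM to 14000 nM.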

Compound 4, half-maximal inhibitory concentration: 11300 nM
The estimate for compound 4 lay 1.6-fold (0.21 log units) below the measured number; the measured number falls inside the stated range.
By their numbers in this assay, from the lowest: compounds 2, 3, 4 and 1 (each within the scatter of the next, the first and the last beyond it).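

In (this assay), 3-chloro-4-methylphenyl on the amide-type nitrogen cannot be separated from either substituted phenyl before it (a 1.6-fold higher number from compound 3 to compound 4 (0.19 log units; within the scatter); a 1.7-fold higher number from compound 2 to compound 4 (0.22 log units; within the scatter)). Unlike compound 2 and compound 3, compound 4 also stays within the scatter of the unsubstituted phenyl (a 1.4-fold lower number from compound 1 to compound 4 (0.14 log units; within the scatter)), so a substituted phenyl at this position does not always separate from phenyl itself.

Going by these compounds, whether a methoxy group, an amine or a carboxylic acid on this phenyl ring would give a step beyond the scatter stays open. Nothing available explains the differences among these compounds.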